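Pyridin-2-yl in place of 2-fluorophenyl

The source may report more compounds than this note shows. Statements on the series, on what has been measured and on what is new or still open speak of the compounds shown alone.

In a functional assay on A549 cells (Homo sapiens) for antiproliferative activity, read by MTT assay, with a stated time of 72 h (a lower number here means a stronger inhibitor, a higher number a weaker inhibitor), compound 3 (`Nc1nc(N)c2cc(CSC(=S)N3CCN(c4ccccc4F)CC3)ccc2n1`) gives 6460 nM and compound 1 (`Nc1nc(N)c2cc(CSC(=S)N3CCN(C4CCCCC4)CC3)ccc2n1`) gives 4710 nM, a pair separated by a 1.4-fold higher number from compound 1 to compound 3 (0.14 log units; within the scatter). Compound 2 (`Nc1nc(N)c2cc(CSC(=S)N3CCN(c4ccc(F)cc4)CC3)ccc2n1`) gives 2040 nM, and the measurements show a 3.2-fold higher number from compound 2 to compound 3 (0.50 log units; beyond the scatter).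

Compound 4 (`Nc1nc(N)c2cc(CSC(=S)N3CCN(c4ccccn4)CC3)ccc2n1`) carries pyridin-2-yl in place of 2-fluorophenyl on an amine nitrogen in a ring. Among the measured compounds shown here, no measured compound has a hetero atom in the ring at this place, so no measured step shows this change directly. For the measured compounds named here, the only guide is how far changes at this nitrogen have moved the number so far. Compound 2 differs from compound 1 by a 2.3-fold lower number from compound 1 to compound 2 (0.36 log units; beyond the scatter), and the largest step seen is the one between compound 2 and compound 3 given above. A small shift is therefore expected, with no more than a modest step in either direction and a slight lean towards compound 2. The expected change is a 1.5-fold lower number from compound 3 to compound 4 (0.19 log units; within the scatter). For compound 4 the estimated value is 4200 nM, with an expected range of 1800 nM to 9500 nM.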

Compound 4, half-maximal inhibitory concentration: 3960 nM
For compound 4 the middle estimate is 1.1-fold (0.03 log units) above the measured one, within the range that was stated.
By their numbers in this assay, from the lowest: compounds 2, 4, 1 and 3 (each within the scatter of the next, the first and the last beyond it).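

Pyridin-2-yl is the first ring at this place with a hetero atom and a hydrogen-bond acceptor, and in this assay it leaves the number within the scatter of all three earlier compounds (a 1.6-fold lower number from compound 3 to compound 4 (0.21 log units; within the scatter); a 1.9-fold higher number from compound 2 to compound 4 (0.29 log units; within the scatter); a 1.2-fold lower number from compound 1 to compound 4 (0.08 log units; within the scatter)). Compound 4 therefore sides with neither fluorophenyl compound, although those two lie beyond the scatter of each other, and this position accepts a ring nitrogen here without a step that can be told from the scatter. No measurement offered here accounts for this result.

Still open, on these data alone, is whether pyridin-3-yl or pyridin-4-yl would stay as close to these compounds as pyridin-2-yl does. Also open, as far as these compounds go, is how a pyrimidin-2-yl ring or a methoxy-bearing phenyl ring on this nitrogen would read in this assay.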